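The compounds below may be only part of what the source reports. "The series", "measured", "known", "first", "only" and "open" are said of these compounds alone.

Measured so far:
- compound 1 `N#Cc1ccc(/C=C/S(=O)(=O)Cc2ccc(Nc3ncnc4ccccc34)cc2)cc1`: > 100000 nM (a limit, not a number)
- compound 2 `O=S(=O)(/C=C/c1ccc(Cl)cc1Cl)Cc1ccc(Nc2ncnc3ccccc23)cc1`: 2000 nM

Within the data shown here, in a functional assay on UACC-62 cells (Homo sapiens) (on this read-out lower numbers stand for stronger inhibition of growth and higher numbers for weaker inhibition of growth), compound 2 gives 2000 nM, the only true number so far. Compound 1 sits at the limit of > 100000 nM in this assay, at which 1 of the 2 values shown sits.

Compound 3 `O=S(=O)(/C=C/c1ccc(O)cc1)Cc1ccc(Nc2ncnc3ccccc23)cc1` is not yet measured. It replaces the 2,4-dichlorophenyl of compound 2 with 4-hydroxyphenyl, on a double-bonded chain carbon bound to a double-bonded chain carbon: 4-hydroxyphenyl in place of 2,4-dichlorophenyl on a double-bonded chain carbon bound to a double-bonded chain carbon.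

Among the measured compounds shown here, one measured step bears on this place, and it is large: an at least 50-fold lower number from compound 1 to compound 2 (1.69 log units; beyond the scatter). For the measured compounds named here, it is the only guide, and it involves neither end of the new change except the 2,4-dichlorophenyl group. Losing that group is expected to give back part of this step, so a higher number is expected in this assay. The expected step is a 5.0-fold higher number from compound 2 to compound 3 (0.70 log units; beyond the scatter). The estimate for compound 3 is 10000 nM, with an expected range of 2000 nM to 80000 nM.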

Compound 3, concentration for 50% growth inhibition: 100000 nM
Beside the measured number, compound 3's estimate is 10-fold (1.00 log units) below it; the whole stated range lies below it.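

In this assay, the step of a 50-fold higher number from compound 2 to compound 3 (1.70 log units; beyond the scatter) shows that the loss seen with 4-cyanophenyl at this place is not unique to that group: 4-hydroxyphenyl also gives up the growth inhibition of compound 2. Among the three groups shown on the double-bonded chain carbon, 2,4-dichlorophenyl therefore stands alone, with both of its replacements giving much weaker inhibition. The remaining step, a number no higher from compound 1 to compound 3 (the limit leaves the size open), gives a direction only, and its size cannot be read. Compound 1 stands at a limit and not at a number: the limit of > 100000 nM in this assay, at which 1 of the 3 values shown sits.

Still open, going by these compounds, is whether both chlorines are needed, or whether a single chlorine on the aromatic ring would keep the inhibition of compound 2. On these data alone, how an unsubstituted phenyl, a methoxy group or an amine on that ring would compare also remains open.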